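Methoxymethoxy in place of amino on the chalcone ring

A few compounds are considered here, and "the series" means these few. Any claim that something is new, unique, unknown or untested is made for them only; others in the source may bear on it.

Two chalcone-like boronic esters share one core. Compound 1 `O=C(/C=C/c1ccc2c(c1)B(O)OC2)c1cccc(F)c1` carries a fluoro group on the ketone-side aromatic ring, and in a functional assay on SK-OV-3 cells (Homo sapiens) for cytotoxicity, read by MTT assay, with a stated time of 48 h (a higher number here means a weaker inhibitor, a lower number a stronger inhibitor), compound 1 gives 4800 nM. Compound 2 `Nc1cccc(C(=O)/C=C/c2ccc3c(c2)B(O)OC3)c1` carries an amino group in its place, and in this assay compound 2 gives 7400 nM. Going by the values given here, the only measured step is a 1.5-fold higher number from compound 1 to compound 2 (0.19 log units; within the scatter), so compound 2 stands with the higher of the two numbers, yet within the scatter of compound 1.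

Compound 3 `COCOc1cccc(C(=O)/C=C/c2ccc3c(c2)B(O)OC3)c1` differs from compound 2 in one place: methoxymethoxy in place of amino on an aromatic carbon. Among the compounds with values here, no measured step bears directly on a methoxymethoxy group; the single step from fluoro to amino was within the scatter, which gives no sign that substituents at this position move the number much. Compound 3 is therefore expected to show a 1.2-fold lower number from compound 2 to compound 3 (0.09 log units; within the scatter), a step that stays within the scatter. Compound 3 is estimated at 6000 nM, within 2000 nM to 18000 nM.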

Compound 3, half-maximal inhibitory concentration: 11700 nM
Compound 3: middle estimate off by 2.0-fold (0.29 log units), on the low side, and the stated range covers the measured number.
By their numbers in this assay, from the lowest: compounds 1, 2 and 3 (each within the scatter of the next, the first and the last beyond it).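

In this assay, this position now gives its first step beyond the scatter: with methoxymethoxy in place of fluoro, the result is a 2.4-fold higher number from compound 1 to compound 3 (0.39 log units; beyond the scatter). Going by these compounds alone, with methoxymethoxy in place of amino, the result is a 1.6-fold higher number from compound 2 to compound 3 (0.20 log units; within the scatter), so methoxymethoxy separates from fluoro but not from amino, and the only step beyond the scatter at this position runs toward a weaker inhibitor and is modest. No measurement at hand accounts for the difference between these two steps.

The compounds shown leave open whether a carboxylic acid, a nitrile or a longer alkoxy chain on this aromatic carbon would shift the number in either direction. They also leave open whether any group here could give a number clearly lower than that of compound 1.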